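Carboxy in Place of Benzyloxy on an Acyltransferase Inhibitor

The compounds below may be only part of what the source reports. "The series", "measured", "known", "first", "only" and "open" are said of these compounds alone.

Compound 1, `COc1ccc(C2(CNC(=O)Nc3c(C(C)C)cccc3C(C)C)CCCC2)cc1`: 31 nM
Compound 2, `CC(C)c1cccc(C(C)C)c1NC(=O)NCC1(c2cccc(OCc3ccccc3)c2)CCCC1`: 30 nM

In an assay on microsomes for inhibition of acyl-CoA:cholesterol acyltransferase (Oryctolagus cuniculus) (on this read-out lower numbers stand for stronger inhibition and higher numbers for weaker inhibition), compound 2 gives the lowest of the two numbers, but its nearest neighbour, compound 1, lies within the scatter, so the two cannot be told apart. Compound 3, `CC(C)c1cccc(C(C)C)c1NC(=O)NCC1(c2cccc(C(=O)O)c2)CCCC1`, has not yet been measured. It differs from compound 2 in one place: carboxy in place of benzyloxy on an aromatic carbon. Among the measured compounds shown here, no measured pair shows a change of this kind, so the expectation rests on the change alone. Compound 3 is expected to give a clearly higher number than compound 2, a step of a 20-fold higher number from compound 2 to compound 3 (1.30 log units; beyond the scatter) beyond the scatter. The estimate for compound 3 is 600 nM, with a range from 100 nM to 5000 nM.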

Compound 3, half-maximal inhibitory concentration: 620 nM
For compound 3 the middle estimate is 1.0-fold (0.01 log units) below the measured one; low and high end bracket the measured number.
By their numbers in this assay, from the lowest: compounds 2 and 1 (each within the scatter of the next); then compound 3.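

In this assay, this aromatic position proves sensitive to what it carries: a 21-fold higher number from compound 2 to compound 3 (1.32 log units; beyond the scatter) follows from carboxy in place of benzyloxy, so inhibition weakens markedly. The step of a 20-fold higher number from compound 1 to compound 3 (1.30 log units; beyond the scatter) points the same way, with 3-carboxyphenyl in place of 4-methoxyphenyl on a saturated ring carbon. No measurement at hand explains this loss.

Going by these compounds, it remains open whether the loss follows from the arrival of the carboxy group or the departure of the benzyloxy ring. A methyl ester or a hydroxy group in this place could help separate the two.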